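The source may hold more compounds than are shown below. What is called first, only, known or untested is meant among the compounds shown, and "the series" means these compounds.

Of the compounds shown here, three have so far been tested in an ADME assay on HCT-116 cells (Homo sapiens) for cytotoxicity, read by CellTiter-Glo, with a stated time of 72 h; a lower number here means a stronger inhibitor, a higher number a weaker inhibitor. Compound 1 `COc1ccccc1-c1ccc(S(=O)(=O)N2CCC(N3CCC(C)CC3)CC2)cc1` reaches only the limit of the assay there, giving > 5000 nM. Compound 2 `CC1CCN(C2CCN(S(=O)(=O)c3ccc(-c4ccccc4)cc3)CC2)CC1` likewise gives only a limit, > 5000 nM. Compound 3 `COc1cccc(S(=O)(=O)N2CCC(N3CCC(C)CC3)CC2)c1` also gives only a limit, > 5000 nM. Compound 1 differs from compound 2 by methoxy in place of hydrogen on an aromatic carbon, and the resulting step that the two limits leave unreadable from compound 2 to compound 1 cannot be sized because of the limit of > 5000 nM in this assay, at which 3 of the 3 values shown sit. Compound 4 `COc1ccc(OC)c(S(=O)(=O)N2CCC(N3CCC(C)CC3)CC2)c1` has not yet been measured. It differs from compound 3 by methoxy in place of hydrogen on an aromatic carbon, which is the same kind of change as that from compound 2 to compound 1, though here the place is additionally para to a methoxy group. How the core of compound 2 differs from the core of compound 3 is not broken down here. The step expected from compound 3 to compound 4 in this assay is a step that the limit leaves unreadable from compound 3 to compound 4, sitting beside the earlier unreadable one, and this expectation rests on (the limit of > 5000 nM in this assay, at which 3 of the 3 values shown sit). Compound 4 is therefore estimated to give 8000 nM, with a plausible range from 4000 nM to 20000 nM, and most likely to show only a limit once more.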

Compound 4, half-maximal inhibitory concentration: > 5000 nM
Compound 4: only a limit was reported; the forecaster's own chance of this, stated with the estimate: 85%; the middle value lies beyond the limit too.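

Compound 3 and compound 4 both give only a limit, so no size can be read for the step between them: the limit of > 5000 nM in this assay, at which 4 of the 4 values shown sit.

The compounds shown leave open how large either methoxy step really is, and what concentration, if any, would give a measurable half-maximal value for these compounds in this assay.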